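Changing one aromatic group on compound 1

A few compounds are considered here, and "the series" means these few. Any claim that something is new, unique, unknown or untested is made for them only; others in the source may bear on it.

For the measured compounds named here, in an ADME assay on HT-29 cells (Homo sapiens) for cytotoxicity, read by MTT assay, with a stated time of 72 h (on this read-out lower numbers stand for stronger inhibition and higher numbers for weaker inhibition), compound 1 `COc1ccc(OC)c(C2=C(c3cc(OC)c(OC)c(OC)c3)C(=O)CC2O[SiH2]C(C)(C)C)c1` gives 5 ug/mL, the only true number among the three compounds measured so far. Compound 2 `COc1ccc(C2=C(c3cc(OC)c(OC)c(OC)c3)CC(O[SiH2]C(C)(C)C)C2=O)cc1[N+](=O)[O-]`, which has a different aromatic group among its differences, gives > 100 ug/mL, and this is a limit of the assay. Compound 3 `COc1ccc(OC)c(C2=C(c3cc(OC)c(OC)c(OC)c3)C(=O)CC2O)c1` gives > 100 ug/mL, again a limit. Compound 4 `COCOc1cc(C2=C(c3cc(OC)c(OC)c(OC)c3)C(=O)CC2O[SiH2]C(C)(C)C)ccc1OC` has not been measured, and its change is 4-methoxy-3-(methoxymethoxy)phenyl in place of 2,5-dimethoxyphenyl on a double-bonded ring carbon. Going by the values given here, the one measured step is an at least 20-fold higher number from compound 1 to compound 3 (1.30 log units; beyond the scatter), so a single change can move this assay a long way. Among the compounds with values here, compound 4 keeps the group involved in that step, however, so no measured step covers this aromatic swap directly. Compound 2 does carry another aromatic group and stays at the limit of > 100 ug/mL, so a moderate move toward weaker inhibition is expected. The estimated step is a 2.0-fold higher number from compound 1 to compound 4 (0.30 log units; within the scatter). For compound 4 the expected value is 10 ug/mL, with an estimated range from 2 ug/mL to 60 ug/mL.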

Compound 4, half-maximal inhibitory concentration: 43 ug/mL
Compound 4: the middle estimate sits 4.3-fold (0.63 log units) below what was measured; the range from low to high includes it.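

The aromatic group on the double-bonded ring carbon matters in this assay: replacing 2,5-dimethoxyphenyl with 4-methoxy-3-(methoxymethoxy)phenyl gives an 8.6-fold higher number from compound 1 to compound 4 (0.93 log units; beyond the scatter) and so weakens inhibition measurably. For the compounds shown here, the earlier single-change step concerned the group on an oxygen on a saturated carbon, so this is the first direct reading of a change at this aromatic position. Even so, compound 4 keeps a true number and does not join the compounds that sit at the limit: the limit of > 100 ug/mL in this assay, at which 2 of the 4 values shown sit.

This one swap changes both the methoxy pattern and the methoxymethoxy group, so the effect of each alone stays unresolved. As far as these compounds go, how a phenyl carrying an amine or a plain hydroxyl at this place would read also remains open.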